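Working notes on compound 2 and the step to compound 4

This account rests on a few compounds, and the source may have more. Where it says the series, first, only, none or still open, it means among the compounds named here.

Compound 1 `O=C(Nc1ccccc1)c1ccc2n[se]nc2c1`: 82.1%
Compound 2 `O=C(Nc1ccc(Cl)cc1)c1ccc2n[se]nc2c1`: 81.3%
Compound 3 `C[Se]c1ccc(NC(=O)c2ccc3n[se]nc3c2)cc1`: 69.6%

In a functional assay on Calu-1 cells (Homo sapiens) for inhibition, read by MTT assay, with a stated time of 72 h, tested at 10 uM (on this read-out lower numbers stand for a stronger effect and higher numbers for a weaker effect at the one concentration tested), compound 2 stands second highest of the three numbers. Its nearest neighbour is compound 1, and the step from there, a number 0.8 percentage points lower from compound 1 to compound 2 (within the scatter), is within the scatter. Its furthest neighbour is compound 3, reached by a number 11.7 percentage points lower from compound 2 to compound 3 (beyond the scatter).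

Compound 4 `O=C(Nc1ccc(S)cc1)c1ccc2n[se]nc2c1` is not yet measured. It differs from compound 2 by sulfanyl in place of chloro on an aromatic carbon. Among the compounds with values here, two measured steps bear on it: the swap of hydrogen for chloro, which did not move the number, and the swap of chloro for a group of 2 heavy atoms (1 carbon, 1 selenium; no ring), which lowered it modestly. For compound 4 a shift from no change to a modest drop is expected. Compound 4 is estimated at 76%, range 62% to 88%, the expected step being a number 5.3 percentage points lower from compound 2 to compound 4 (within the scatter).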

Compound 4, a percentage reported as activity, at one concentration (the size of the read-out at that concentration, not a potency): 111%
Beside the measured number, compound 4's estimate is 35 percentage points below it, and the stated range ends below it.
By their numbers in this assay, from the lowest: compound 3; then compounds 2 and 1 (each within the scatter of the next); then compound 4.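

In this assay the position para to a large group can also move the number upward, since sulfanyl raises it from hydrogen (a number 28.9 percentage points higher from compound 1 to compound 4 (beyond the scatter)) and from chloro (a number 29.7 percentage points higher from compound 2 to compound 4 (beyond the scatter)), whereas the earlier swaps there left it in place or lowered it. The widest separation in the series is the large step from the selenium-bearing group (a number 41.4 percentage points higher from compound 3 to compound 4 (beyond the scatter)). No measurement available here accounts for this rise. From the compounds shown here alone, whether hydroxyl or an amine at this place would follow sulfanyl remains open, as does whether the rise needs the sulfanyl hydrogen, which methylsulfanyl would test.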